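Carboxylate to tetrazole: a swap at the piperazine position

The source may hold more compounds than are shown below. What is called first, only, known or untested is meant among the compounds shown, and "the series" means these compounds.

Compound 2 `O=C(Nc1nc(-c2cccc(C(F)(F)F)c2F)cs1)c1cnc(N2CCNC(C(=O)O)C2)c(Cl)c1` is the more lipophilic of the two measured compounds: in a physicochemical assay for lipophilicity (a higher number here means a more lipophilic compound, a lower number a more polar compound), compound 2 gives 1.88, while compound 1 `C[C@@H](Nc1ncc(C(=O)Nc2nc(-c3cccc(C(F)(F)F)c3F)cs2)cc1Cl)C(=O)O` gives 1.57. Within the data shown here, the only measured step, a number 0.31 log units higher from compound 1 to compound 2 (beyond the scatter), is modest and concerns a different exchange at the same aromatic carbon. Compound 3 `O=C(Nc1nc(-c2cccc(C(F)(F)F)c2F)cs1)c1cnc(N2CCC(c3nn[nH]n3)CC2)c(Cl)c1` carries the change (4-(2H-tetrazol-5-yl)piperidin-1-yl in place of 3-carboxypiperazin-1-yl on an aromatic carbon). Among the measured compounds shown here, no measured pair shows this exchange directly, so the expectation rests on the loose analogy that the one step recorded at this position shifted the read-out upward by a small amount. A comparable small upward shift is therefore expected here, a number 0.32 log units higher from compound 2 to compound 3 (beyond the scatter), though a result within the scatter would not be surprising. For compound 3 the estimate in this assay is 2.2, with a range from 1.6 to 2.8.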

Compound 3, distribution coefficient: 3.24
Compound 3: the middle estimate sits 1.04 log units below what was measured; the measured number lies above the stated range.
By their numbers in this assay, from the lowest: compound 1; then compound 2; then compound 3.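

Replacing 3-carboxypiperazin-1-yl with 4-(2H-tetrazol-5-yl)piperidin-1-yl gives a number 1.36 log units higher from compound 2 to compound 3 (beyond the scatter) in this assay and so shows that this aromatic carbon can carry a far larger change in the read-out than the earlier step of a number 0.31 log units higher from compound 1 to compound 2 (beyond the scatter) had revealed. Measured against the (1-carboxyethyl)amino group, the same entering group gives a number 1.67 log units higher from compound 1 to compound 3 (beyond the scatter) on the same scale, so the two large steps share compound 3 as their higher end. Nothing available accounts for the size of these steps.

The tetrazole and the piperidine ring enter together, so the compounds shown leave open how the step divides between them. A piperidine carrying a carboxylic acid, or a piperazine carrying the tetrazole, on this aromatic carbon would separate the two parts of the change.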